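The source may report more compounds than this note shows. Statements on the series, on what has been measured and on what is new or still open speak of the compounds shown alone.

Compound 2, with the structure `Cc1ccc(NC(=O)NC(=O)c2ccc(OCc3cccc(F)c3)cc2)cc1-c1nc2ccccc2[nH]1`, gives 39600 nM in a functional assay on SW-620 cells (Homo sapiens) for inhibition, read by MTT assay, with a stated time of 48 h; a higher number here means a weaker inhibitor, a lower number a stronger inhibitor. Compound 1, the structure `Cc1ccc(NC(=O)NC(=O)c2ccc(OCc3cccc(Cl)c3Cl)cc2)cc1-c1nc2ccccc2[nH]1`, gives 42100 nM in this assay, and the two values lie within the scatter of each other, so neither stands apart on the numbers available. The step from compound 2 to compound 3, the structure `Cc1ccc(NC(=O)NC(=O)c2ccc(OCc3ccc(Cl)c(Cl)c3)cc2)cc1-c1nc2ccccc2[nH]1`, is 3,4-dichlorophenyl in place of 3-fluorophenyl on a saturated chain carbon bound to an oxygen on an aromatic ring. Among the measured compounds shown here, the one measured step that bears on this change is a 1.1-fold lower number from compound 1 to compound 2 (0.03 log units; within the scatter), which exchanged one halogenated phenyl for another at the same place and left the number essentially unchanged. On that basis a move from 3-fluorophenyl to 3,4-dichlorophenyl at this place is expected to give no step beyond the scatter, and the estimate for compound 3 is 40000 nM, with a range from 18000 nM to 90000 nM. This expected step reads a 1.0-fold higher number from compound 2 to compound 3 (0.00 log units; within the scatter).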

Compound 3, half-maximal inhibitory concentration: 6100 nM
The estimate for compound 3 lay 6.6-fold (0.82 log units) above the measured number; the whole stated range lies above it.
By their numbers in this assay, from the lowest: compound 3; then compounds 2 and 1 (each within the scatter of the next).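

The place on a saturated chain carbon bound to an oxygen on an aromatic ring had seemed indifferent to which halogenated phenyl it carried, but it does respond in this assay: 3,4-dichlorophenyl gives a 6.5-fold lower number from compound 2 to compound 3 (0.81 log units; beyond the scatter) and also a 6.9-fold lower number from compound 1 to compound 3 (0.84 log units; beyond the scatter) when it replaces 2,3-dichlorophenyl. The second step is the more telling, since both groups are dichlorophenyl, so the presence of two chlorines alone does not set compound 3 apart and the arrangement of the chlorines matters here. No measurement at hand explains this difference.

As far as these compounds go, it remains open whether both chlorines of the 3,4-dichlorophenyl group are needed, which a 4-chlorophenyl or 3-chlorophenyl group would address. Also unresolved is how a 4-trifluoromethylphenyl group or a pyridine ring would fare at this place.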